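From compound 3 to compound 4 in this assay

The source may report more compounds than this note shows. Statements on the series, on what has been measured and on what is new or still open speak of the compounds shown alone.

Of the compounds shown here, three that share one core have been measured in a physicochemical assay for inhibition, read by spectrophotometry, with a stated time of 24 h, tested at 2.5 mM; on this read-out lower numbers stand for less inhibition and higher numbers for more inhibition at the one concentration tested (going by the name of the read-out). Compound 1 `COc1cc(/C=N/NC(=O)CCN2CCN(c3ccnc4cc(Cl)ccc34)CC2)ccc1O` gives 50.7% in this assay. Compound 2 `CN(C)c1ccc(/C=N/NC(=O)CCN2CCN(c3ccnc4cc(Cl)ccc34)CC2)cc1` gives 94.2%, and compound 3 `O=C(CCN1CCN(c2ccnc3cc(Cl)ccc23)CC1)N/N=C/c1ccccc1Cl` gives 87.3%. On these numbers compound 3 stands second highest of the three; nearest to it on the numbers is compound 2, within the scatter, and furthest is compound 1, beyond it. Two measured steps lead to compound 3: a number 36.6 percentage points higher from compound 1 to compound 3 (beyond the scatter) and a number 6.9 percentage points lower from compound 2 to compound 3 (within the scatter). Compound 4 `CC(C)c1ccc(/C=N/NC(=O)CCN2CCN(c3ccnc4cc(Cl)ccc34)CC2)cc1` has not yet been measured in this assay; it differs from compound 3 by 4-isopropylphenyl in place of 2-chlorophenyl on a carbon with a double bond to nitrogen. For the measured compounds named here, no measured step brings in a 4-isopropylphenyl group, so the nearest guide is the step between compound 2 and compound 3, where one aromatic group replaced another and the number stayed within the scatter, while only compound 1 lies far lower. It is therefore expected that the step of a number 2.3 percentage points lower from compound 3 to compound 4 (within the scatter) stays within the scatter. Compound 4 is estimated at 85%, with a range from 65% to 97%.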

Compound 4, a percentage reported as inhibition, at one concentration (the size of the read-out at that concentration, not a potency): 94%
The estimate for compound 4 lay 9 percentage points below the measured number; low and high end bracket the measured number.
By their numbers in this assay, from the lowest: compound 1; then compounds 3, 4 and 2 (each within the scatter of the next).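

In this assay a purely hydrocarbon substituent on the phenyl ring, at the place on a carbon with a double bond to nitrogen, leaves the number level: isopropyl in place of dimethylamino gives a number 0.2 percentage points lower from compound 2 to compound 4 (within the scatter) and so shows that the dimethylamino nitrogen is not required for a high reading among these compounds. The step to 4-isopropylphenyl from 2-chlorophenyl, a number 6.7 percentage points higher from compound 3 to compound 4 (within the scatter), likewise leaves the reading unchanged within the scatter, while a number 43.3 percentage points higher from compound 1 to compound 4 (beyond the scatter) makes 4-hydroxy-3-methoxyphenyl the only group shown here that stands apart, as compounds 2, 3 and 4 all read beyond the scatter of compound 1. Nothing available explains why that group differs.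

Going by these compounds, whether the hydroxy or the methoxy group, or only the two together, goes with the low reading of compound 1 stays open. On these data alone, how a phenyl carrying a carboxylic acid would read at this place also stays open.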